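This account rests on a few compounds, and the source may have more. Where it says the series, first, only, none or still open, it means among the compounds named here.

Measured compounds so far:
- compound 1, `COc1ccc(-c2nc(CNc3ccc(C(=O)NO)cc3)n(-c3ccccc3)n2)cc1`: 77.6%
- compound 2, `Cc1ccccc1-n1nc(-c2ccccc2)nc1CNc1ccc(C(=O)NO)cc1`: 57.1%
- compound 3, `O=C(NO)c1ccc(NCc2nc(-c3ccc(Cl)c(Cl)c3)nn2-c2ccccc2)cc1`: 34.5%

All three were read in an assay on Sf9 cells for inhibition of protein deacetylase HDAC6 (Homo sapiens), read by fluorescence, with a stated time of 40 min, tested at 100 nM; on this read-out higher numbers stand for more inhibition at the one concentration tested (going by the name of the read-out) and lower numbers for less inhibition. Compound 2 stands second highest of the three numbers: compound 1 sits above it by a gap beyond the scatter, and compound 3 sits below it by a gap that is also beyond the scatter. Within the data shown here, the one single-place step in the set is a number 43.1 percentage points lower from compound 1 to compound 3 (beyond the scatter), a large fall brought on by the aryl group on the aromatic carbon of the shared core.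

Compound 4, `Cc1cc(C)cc(-n2nc(-c3ccccc3)nc2CNc2ccc(C(=O)NO)cc2)c1`, is not yet measured. Relative to compound 2 it differs at a different position: 3,5-dimethylphenyl in place of 2-methylphenyl on an aromatic nitrogen. Among the measured compounds shown here, no measured pair changes the aryl group on the aromatic nitrogen, so the step to compound 4 has no direct precedent in this assay; the step from compound 1 to compound 3 concerns the other aryl position and does not bear on it. For the measured compounds named here, compound 1 and compound 2 differ in two places at once and show only that their two values lie well apart.

With nothing to suggest a shift at this position, the expectation is a step of a number 4.1 percentage points lower from compound 2 to compound 4 (within the scatter), that is no change beyond the scatter. Compound 4 is therefore estimated at 53%, within 32% to 72%.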

Compound 4, a percentage reported as inhibition, at one concentration (the size of the read-out at that concentration, not a potency): 49.8%
Estimate against measurement, compound 4: 3.2 percentage points above; measured number inside the range.
By their numbers in this assay, from the lowest: compound 3; then compounds 4 and 2 (each within the scatter of the next); then compound 1.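

In this assay, placing 3,5-dimethylphenyl instead of 2-methylphenyl on the aromatic nitrogen gives a number 7.3 percentage points lower from compound 2 to compound 4 (within the scatter), the first step read at this position. For these two methyl-bearing phenyl groups, with a phenyl group on the aromatic carbon of the shared core, the read-out therefore shows no shift beyond the scatter, while the change at the other aryl position, a number 43.1 percentage points lower from compound 1 to compound 3 (beyond the scatter), stands as a large one. Nothing available speaks to what lies behind the outcome at the aromatic nitrogen.

From the compounds shown here alone, both compounds in this step carry only methyl groups on the aryl ring at this position, so it remains open whether a ring bearing an amine, a carboxylic acid or a longer alkyl chain would read the same way, or whether a pyridine ring in place of the phenyl ring would do so. Also open, going by these compounds, is whether the same change gives a step within the scatter when the aromatic carbon carries 4-methoxyphenyl or 3,4-dichlorophenyl rather than phenyl.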